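A few compounds are considered here, and "the series" means these few. Any claim that something is new, unique, unknown or untested is made for them only; others in the source may bear on it.

Measured in a functional assay on MIA PaCa-2 cells (Homo sapiens) for inhibition, read by MTT assay, with a stated time of 72 h; on this read-out lower numbers stand for stronger inhibition and higher numbers for weaker inhibition:
- compound 1 `COc1cc(NC(C)CCCNC(=O)Nc2cccc(F)c2)c2ncccc2c1` gives 22000 nM
- compound 2 `COc1cc(NC(C)CCCNC(=O)NNC(=O)Nc2ccc(F)cc2)c2ncccc2c1` gives >= 250000 nM (a limit)
- compound 3 `COc1cc(NC(C)CCCNC(=O)NNC(=O)Nc2ccc(Cl)cc2)c2ncccc2c1` gives >= 250000 nM (a limit)

Compound 3 is known only as a limit, >= 250000 nM. Compound 2 sits at the same limit, as the limit of >= 250000 nM in this assay, at which 2 of the 3 values shown sit, records.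

Compound 4 `COc1cc(NC(C)CCCNC(=O)Nc2ccc(F)cc2)c2ncccc2c1` differs from compound 3 as follows: 4-fluorophenyl in place of ((4-chlorophenyl)carbamoyl)amino on an amide-type nitrogen. Within the data shown here, two measured steps bear on this change, and they run the opposite way: an at least 11-fold higher number from compound 1 to compound 2 (1.05 log units; beyond the scatter) and an at least 11-fold higher number from compound 1 to compound 3 (1.05 log units; beyond the scatter). Both are large. Compound 4, like compound 1, has a fluorophenyl on the amide-type nitrogen, so a large fall in the number is expected in this assay. The expected step is an at least 12-fold lower number from compound 3 to compound 4 (1.09 log units; beyond the scatter). Compound 4 is estimated at 20000 nM, with an expected range of 8000 nM to 55000 nM.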

Compound 4, half-maximal inhibitory concentration: 21000 nM
Compound 4: middle estimate off by 1.1-fold (0.02 log units), on the low side; measured number inside the range.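

With 4-fluorophenyl on the amide-type nitrogen, this assay shows an at least 11-fold lower number from compound 3 to compound 4 (1.07 log units; beyond the scatter) and an at least 11-fold lower number from compound 2 to compound 4 (1.07 log units; beyond the scatter). Both steps start from a limit, not a number: the limit of >= 250000 nM in this assay, at which 2 of the 4 values shown sit.

Exchanging 3-fluorophenyl for 4-fluorophenyl gives a 1.0-fold lower number from compound 1 to compound 4 (0.02 log units; within the scatter), so the two fluorophenyl groups cannot be told apart at this position.

Still open, from the compounds shown here alone, is how an amine or a carboxylic acid on the phenyl ring, or a longer chain on the amide-type nitrogen, would read here. The ((4-fluorophenyl)carbamoyl)amino and ((4-chlorophenyl)carbamoyl)amino groups cannot be ranked, as the step between compound 2 and compound 3 cannot be read.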